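Adding an Oxan-4-yl Group to the Pyrazole Nitrogen

The source may report more compounds than this note shows. Statements on the series, on what has been measured and on what is new or still open speak of the compounds shown alone.

Among the measured compounds shown here, compound 1, with the structure `Cc1cc(Nc2nc(NCc3ccc(F)cc3F)nc3[nH]ncc23)n[nH]1`, is the only member of this small set for which a number has been reported. In an assay on isolated protein for inhibition of serine/threonine-protein kinase PAK 4 (Homo sapiens), read by HTRF, with a stated time of 60 min (a lower number here means a stronger inhibitor, a higher number a weaker inhibitor), compound 1 gives 96.1 nM. Its two companions were examined but left without a result: compound 2, with the structure `Cc1cc(Nc2nc(NCc3ccc(F)c(F)c3)nc3[nH]ncc23)n[nH]1`, shows "nd" (no result reported) in this assay, and compound 3, with the structure `Cc1cc(Nc2nc(NCc3c(F)cc(F)cc3F)nc3[nH]ncc23)n[nH]1`, likewise shows "nd" (no result reported) there. Compound 1 therefore stands alone as the reference point, with nothing above or below it to compare against.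

Compound 4, with the structure `Cc1cc(Nc2nc(NCc3ccc(F)cc3F)nc3c2cnn3C2CCOCC2)n[nH]1`, carries one alteration relative to compound 1: oxan-4-yl in place of hydrogen on an aromatic nitrogen. For the measured compounds named here, no pair of measured compounds differing in the same way is available, so the size and direction of the effect of this change cannot be read from the data.

In the absence of such a step, the expectation for compound 4 is taken to lie close to compound 1, allowing for some loss that may or may not exceed the scatter. The step from compound 1 to compound 4 in this assay is thus expected to be a 1.6-fold higher number from compound 1 to compound 4 (0.19 log units; within the scatter). Compound 4 is estimated at 150 nM, within a range from 40 nM to 600 nM.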

Compound 4, half-maximal inhibitory concentration: 1750 nM
Beside the measured number, compound 4's estimate is 12-fold (1.07 log units) below it; the whole stated range lies below it.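

In this assay, among the compounds shown here, oxan-4-yl in place of hydrogen on the aromatic nitrogen gives an 18-fold higher number from compound 1 to compound 4 (1.26 log units; beyond the scatter), the first reading of any change at this position and a large one. The hydrogen on this nitrogen therefore cannot be exchanged for oxan-4-yl without a clear loss of inhibition, although compound 4 still gives a measurable number, so the change weakens inhibition without abolishing it. Nothing available bears on why the number rises.

For the compounds shown here, the single pair cannot separate the loss of the hydrogen from the arrival of this particular six-membered non-aromatic ring, so it remains open whether any group on this nitrogen would do the same or whether the result belongs to oxan-4-yl alone. On these data alone, a methyl group, a longer chain ending in an amine, or a chain carrying a carboxylic acid at the same nitrogen would each help to tell these readings apart, and how far the number would move with any of them stays unknown.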